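Compound 4: replacing the benzylamino group of compound 1

The source may report more compounds than this note shows. Statements on the series, on what has been measured and on what is new or still open speak of the compounds shown alone.

In a functional assay on BaF3 cells (Mus musculus) for antiproliferative activity, read by CCK-8 assay and cell counting, with a stated time of 76 h (a lower number here means a stronger inhibitor, a higher number a weaker inhibitor), compound 1 (`COc1cc2nccc(Oc3ccc(Nc4nn(C)cc4C(=O)NCc4ccccc4)cc3)c2cc1C(N)=O`) gives > 10000 nM which is a limit and not a number. Compound 2 (`COc1cc2nccc(Oc3ccc(Nc4nn(C)cc4C(=O)NC45CCC(CC4)CC5)cc3)c2cc1C(N)=O`) gives > 10000 nM which is likewise a limit. Compound 3 (`COc1cc2nccc(Oc3ccc(Nc4nn(C)cc4C(=O)Nc4ccc(F)cc4)cc3)c2cc1C(N)=O`) gives 3060 nM as a true number, so most of the series sits at the limit of > 10000 nM in this assay, at which 2 of the 3 values shown sit, here. Compound 4 (`COc1cc2nccc(Oc3ccc(Nc4nn(C)cc4C(=O)N4CCCC5CCCCC54)cc3)c2cc1C(N)=O`) differs on the carbonyl carbon: a group of 10 heavy atoms (9 carbon, 1 nitrogen; one six-membered non-aromatic ring of carbon only, one six-membered non-aromatic ring with 1 hetero atom) in place of a group of 8 heavy atoms (7 carbon, 1 nitrogen; one six-membered aromatic ring of carbon only), on a carbonyl carbon describes the change. The only readable gain is an at least 3.2-fold lower number from compound 1 to compound 3 (0.51 log units; beyond the scatter) with 4-fluorophenyl in place of benzyl. The closest measured change to non-aromatic rings is a step that the two limits leave unreadable from compound 1 to compound 2 and it gives no size. No step beyond the scatter is therefore expected in this assay. The estimated step is a number no higher from compound 1 to compound 4 (the limit leaves the size open) on this basis. Compound 4 is expected at 10000 nM with an estimated range of 3000 nM to 30000 nM in this read-out.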

Compound 4, half-maximal inhibitory concentration: 4330 nM
Compound 4: middle estimate off by 2.3-fold (0.36 log units), on the high side, within the range that was stated.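

On the carbonyl carbon, a group with no hydrogen-bond donor and no aromatic ring still gives a readable value in this assay, so neither feature is required here. Gains over both limit compounds are readable (an at least 2.3-fold lower number from compound 1 to compound 4 (0.36 log units; beyond the scatter); an at least 2.3-fold lower number from compound 2 to compound 4 (0.36 log units; beyond the scatter)), and non-aromatic rings alone do not decide the outcome, yet compound 2 carries them too. The 4-fluorophenyl group and the new group cannot be told apart (a 1.4-fold higher number from compound 3 to compound 4 (0.15 log units; within the scatter)).

As far as these compounds go, what a morpholine or a carboxylic acid on this carbonyl carbon would give stays open. Compounds 1 and 2 each give only a limit, and the step between them cannot be read: the limit of > 10000 nM in this assay, at which 2 of the 4 values shown sit.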